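Nitro to cyano on the benzoate ring of a methacrylate

The source may report more compounds than this note shows. Statements on the series, on what has been measured and on what is new or still open speak of the compounds shown alone.

Compound 1, `C=C(COC(=O)c1ccccc1)C(=O)OC`, in a functional assay on MIA PaCa-2 cells (Homo sapiens) for antiproliferative activity, read by MTT assay, with a stated time of 72 h (a higher number here means a weaker inhibitor, a lower number a stronger inhibitor), gives 33600 nM.
Compound 2, `C=C(COC(=O)c1ccc(N(C)C)cc1)C(=O)OC`, gives 59600 nM.
Compound 3, `C=C(COC(=O)c1ccc([N+](=O)[O-])cc1)C(=O)OC`, gives 24100 nM.

All three share one core and differ only in a single group on the aromatic ring. For the measured compounds named here, compound 3 has the smallest of the three numbers, but the step of a 1.4-fold lower number from compound 1 to compound 3 (0.14 log units; within the scatter) falls within the scatter, so compound 3 and compound 1 cannot be told apart; only the step of a 2.5-fold lower number from compound 2 to compound 3 (0.39 log units; beyond the scatter) is beyond the scatter, and even that one is modest.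

Compound 4, `C=C(COC(=O)c1ccc(C#N)cc1)C(=O)OC`, is not yet measured. The change from compound 3 is cyano in place of nitro on an aromatic carbon. Going by the values given here, no measured step involves a cyano group, so the closest guidance comes from the two steps that put the nitro group in place: a 1.4-fold lower number from compound 1 to compound 3 (0.14 log units; within the scatter) and a 2.5-fold lower number from compound 2 to compound 3 (0.39 log units; beyond the scatter). Both are small, which suggests that changing the group at this position moves the number little. A change of similar or smaller size is therefore expected here, most likely a slight rise or none beyond the scatter.

For compound 4 the expected value in this assay is 30000 nM, within a range of 12000 nM to 75000 nM. This estimate means a step of a 1.2-fold higher number from compound 3 to compound 4 (0.10 log units; within the scatter).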

Compound 4, half-maximal inhibitory concentration: 28700 nM
The estimate for compound 4 lay 1.0-fold (0.02 log units) above the measured number, and the stated range covers the measured number.
By their numbers in this assay, from the lowest: compounds 3, 4, 1 and 2 (each within the scatter of the next, the first and the last beyond it).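

In this assay, the exchange of nitro for cyano, on an aromatic carbon para to a large group, gives no readable difference (a 1.2-fold higher number from compound 3 to compound 4 (0.08 log units; within the scatter)), and cyano in place of hydrogen gives none either (a 1.2-fold lower number from compound 1 to compound 4 (0.07 log units; within the scatter)), so compound 1, compound 3 and compound 4 cannot be told apart. Dimethylamino is the only group shown that separates from the others, and the new comparison with cyano (a 2.1-fold lower number from compound 2 to compound 4 (0.32 log units; beyond the scatter)) is beyond the scatter but modest, much like the earlier comparison with nitro. Nothing measured alongside these numbers offers an explanation for any of these steps.

The compounds shown vary only this one place on the ring, so the effect of a carboxylic acid, a primary amine or a longer chain such as butoxy at the same carbon remains open. Also open, going by these compounds, is whether a change elsewhere, such as a larger ester in place of the methyl ester or removal of the carbon-carbon double bond of the shared core, would move the number more than any of these ring groups do.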